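Replacing phenyl on the amine nitrogen of compound 2

The compounds below may be only part of what the source reports. "The series", "measured", "known", "first", "only" and "open" are said of these compounds alone.

- compound 1 `Cc1nn(-c2ccccc2)c(Oc2ccc(-c3nc4cc([N+](=O)[O-])ccc4[nH]3)cc2)c1/C=N/NC(N)=S`: > 100000 nM (a limit)
- compound 2 `Cc1nn(-c2ccccc2)c(Oc2ccc(-c3nc4cc(C(=O)O)ccc4[nH]3)cc2)c1/C=N/Nc1ccccc1`: 90 nM
- compound 3 `Cc1nn(-c2ccccc2)c(Oc2ccc(-c3nc4cc(C(=O)O)ccc4[nH]3)cc2)c1/C=N/NC(N)=S`: not yet measured

Within the data shown here, in a functional assay on MCF7 cells (Homo sapiens) for cytotoxicity, read by sulforhodamine B assay, with a stated time of 48 h, in the presence of a further agent that is not named here (on this read-out lower numbers stand for stronger inhibition of growth and higher numbers for weaker inhibition of growth), compound 2 gives 90 nM, the only actual number so far. The reading for compound 1 is > 100000 nM, which is a limit of the assay and not a number.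

The change from compound 2 to compound 3 is a group of 3 heavy atoms (1 carbon, 1 nitrogen, 1 sulfur; no ring) in place of a group of 6 heavy atoms (6 carbon; one six-membered aromatic ring of carbon only), on an amine nitrogen. Phenyl leaves, and the new group sits on the same amine nitrogen, while the rest of compound 2 stays as it is.

Among the measured compounds shown here, no measured step isolates this change, so any size expected in this assay is a judgement. A move towards weaker growth inhibition, beyond the usual scatter, is expected. That expectation rests on compound 1, which also carries the entering group and whose > 100000 nM is a limit. Compound 3 keeps everything else from compound 2 at 90 nM, so a real number rather than a limit is the more likely outcome. The estimated change is a 6.7-fold higher number from compound 2 to compound 3 (0.82 log units; beyond the scatter). For compound 3 the estimate is 600 nM, with an expected range of 60 nM to 8000 nM.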

Compound 3, concentration for 50% growth inhibition: > 100000 nM
Compound 3 was reported as a limit (the forecaster's own chance of this, stated with the estimate: 10%); at least 160-fold (2.22 log units) between middle value and limit.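

In this assay, replacing phenyl on the amine nitrogen with the group of 3 heavy atoms (1 carbon, 1 nitrogen, 1 sulfur) gives an at least 1100-fold higher number from compound 2 to compound 3 (3.04 log units; beyond the scatter), with the rest of the structure held constant. Compound 3 gives > 100000 nM, which is a limit of the assay and not a number. Compound 1 left open whether its limit went with nitro or with the entering group; compound 3 shows that the entering group still goes with a limit when carboxy stands in place of nitro, but the step between these two compounds cannot be read, as both readings sit at the same ceiling: the limit of > 100000 nM in this assay, at which 2 of the 3 values shown sit.

From the compounds shown here alone, how far compound 3 lies beyond that limit remains unknown, and so does the reading of a compound joining nitro on the core with phenyl on the amine nitrogen. Also open, going by these compounds, is whether the strong growth inhibition of compound 2 needs phenyl itself, or whether a benzyl, a pyridyl or a methyl on the same amine nitrogen would give a measurable number in this assay.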